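The compounds below may be only part of what the source reports. "The series", "measured", "known", "first", "only" and "open" are said of these compounds alone.

Working notes on the series. In a functional assay on the whole organism with Rattus norvegicus as the target (on this read-out lower numbers stand for an effect already at smaller amounts and higher numbers for an effect only at larger amounts of compound), compound 3 `CC(C)(C)Cc1ccc2nc(N)sc2c1` gives > 10 mg/kg, which is a limit of the assay and not a number. Compound 1 `Nc1ccc2nc(N)sc2c1` gives > 10 mg/kg, also a limit. Compound 3 therefore stands at the limit of > 10 mg/kg in this assay, at which 2 of the 3 values shown sit. Compound 2 `CC(C)(C)c1ccc2nc(N)sc2c1` gives a number, 4 mg/kg.

Next is compound 4 `Nc1nc2ccc(CC(F)(F)F)cc2s1`, with trifluoromethyl in place of tert-butyl on a saturated chain carbon bound to an aromatic carbon. Cut one bond further out, the same difference reads neopentyl to 2,2,2-trifluoroethyl.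

Within the data shown here, no measured step covers this exchange directly. The nearest is an at least 2.5-fold higher number from compound 2 to compound 3 (0.39 log units; beyond the scatter), where neopentyl replaces tert-butyl on an aromatic carbon. Also relevant is an at least 2.5-fold lower number from compound 1 to compound 2 (0.39 log units; beyond the scatter), while a step that the two limits leave unreadable from compound 1 to compound 3 gives no usable size. Compound 2 shows with 4 mg/kg that a number can be reached in this assay, so a modest move to a lower number is expected. A further limit remains possible. As an estimate, this reads an at least 1.4-fold lower number from compound 3 to compound 4 (0.15 log units; that floor lies within the scatter). For compound 4 the estimated value is 7 mg/kg, with an expected range from 2.5 mg/kg to 20 mg/kg.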

Compound 4, dose for half-maximal effect: 8 mg/kg
Estimate against measurement, compound 4: 1.1-fold (0.06 log units) below; the measured number falls inside the stated range.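

In this assay compound 3 gives > 10 mg/kg, which is a limit of the assay and not a number. With trifluoromethyl in place of tert-butyl on a saturated chain carbon bound to an aromatic carbon, the series now holds a number for a group with that chain carbon, yet an at least 1.2-fold lower number from compound 3 to compound 4 (0.09 log units; that floor lies within the scatter) and an at least 1.2-fold lower number from compound 1 to compound 4 (0.09 log units; that floor lies within the scatter) give only floors, so neither shows that the exchange moves the read-out beyond the scatter. Against the one earlier number, a 2.0-fold higher number from compound 2 to compound 4 (0.30 log units; within the scatter) leaves 2,2,2-trifluoroethyl and tert-butyl on an aromatic carbon not separated, and every comparison with the other two compounds stays open-ended: the limit of > 10 mg/kg in this assay, at which 2 of the 4 values shown sit.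

The compounds shown leave open how far past the limit compound 1 and compound 3 lie, so the true size of the exchange from neopentyl to 2,2,2-trifluoroethyl remains unknown. Also open, on these data alone, is whether a longer fluorinated chain, a difluoromethyl group or a carboxylic acid on that saturated chain carbon would give a number in this assay or return to the limit.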